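The source may report more compounds than this note shows. Statements on the series, on what has been measured and on what is new or still open speak of the compounds shown alone.

Compound 1 `CCCCC(CCCC)C(O/N=C/C(=O)O)c1ccc(OCc2ccc3ccccc3n2)cc1` and compound 2 `CCCCC(CCCC)C(O/N=C(\C)C(=O)O)c1ccc(OCc2ccc3ccccc3n2)cc1` share a core; in a functional assay for inhibition of Polyunsaturated fatty acid 5-lipoxygenase (Homo sapiens) (a higher number here means a weaker inhibitor, a lower number a stronger inhibitor), compound 1 gives 10 nM, and compound 2 gives 14 nM. The change between them is a group of 6 heavy atoms (3 carbon, 1 nitrogen, 2 oxygen; no ring) in place of a group of 5 heavy atoms (2 carbon, 1 nitrogen, 2 oxygen; no ring), on an oxygen on a saturated carbon and it made a 1.4-fold higher number from compound 1 to compound 2 (0.15 log units; within the scatter).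

Compound 3 `O=C(O)/C=N/OC(c1ccc(OCc2nc3ccccc3s2)cc1)C1CCCCC1` rests on a different core, and the difference between the two cores is not broken down here. In this assay compound 3 gives 60 nM, the highest of the three numbers: compound 2 stands nearest to it, and compound 1 furthest, both beyond the scatter.

Compound 4 `C/C(=N\OC(c1ccc(OCc2nc3ccccc3s2)cc1)C1CCCCC1)C(=O)O` is not yet measured. Within the data shown here, it differs from compound 3 by a group of 6 heavy atoms (3 carbon, 1 nitrogen, 2 oxygen; no ring) in place of a group of 5 heavy atoms (2 carbon, 1 nitrogen, 2 oxygen; no ring), on an oxygen on a saturated carbon, which is the same change as the one from compound 1 to compound 2, made at the same place. Among the compounds shown this change occurs twice in all.

The expectation for compound 4 rests on a single earlier case: in this assay the same change made a 1.4-fold higher number from compound 1 to compound 2 (0.15 log units; within the scatter), a step that lies within the scatter. On that basis the step of a 1.3-fold higher number from compound 3 to compound 4 (0.12 log units; within the scatter) is expected to be small as well, and compound 4 is estimated at 80 nM, with a likely range from 35 nM to 180 nM. Whether the change behaves alike on the core of compound 3 is not shown by any measured pair.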

Compound 4, half-maximal inhibitory concentration: 60 nM
Compound 4: the middle estimate sits 1.3-fold (0.12 log units) above what was measured; low and high end bracket the measured number.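

In this assay, putting the group of 6 heavy atoms in place of the group of 5 heavy atoms, on an oxygen on a saturated carbon, gives no change at the digits printed from compound 3 to compound 4 (within the scatter), so the small step seen on the first core appears again on the core of compound 3. Set side by side, the two steps do not differ beyond what repeated measurements would produce: the same change on two cores in this assay, a 1.4-fold higher number (0.15 log units; within the scatter) from compound 1 to compound 2 and no change at the digits printed (within the scatter) from compound 3 to compound 4, 1.4-fold (0.15 log units) apart, within the scatter of two such steps This shows that the change carried over between these two cores and left the read-out within the scatter each time, but it rests on only two pairs and does not show that the same would hold on any other core, nor does it reveal whether a small real effect lies hidden within the scatter.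

The compounds shown leave open how an ethyl group or a longer chain at this place would behave, and how an ester or an amide in place of the carboxylic acid would read in this assay. No pair shown divides the difference between the two cores into its separate parts, and the contribution of each part to the gap in their values remains unknown.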